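Trifluoromethyl in Place of Acetyl: Cytotoxicity Outlook

A few compounds are considered here, and "the series" means these few. Any claim that something is new, unique, unknown or untested is made for them only; others in the source may bear on it.

Measured compounds:
Compound 1 `Cc1cc(NC(=O)Nc2ncccc2C)c2ccccc2n1`, > 25000 nM
Compound 2 `Cc1cc(NC(=O)Nc2ccccc2C(F)(F)F)c2ccccc2n1`, > 25000 nM
Compound 3 `CC(=O)c1ccc(NC(=O)Nc2cc(C)nc3ccccc23)cc1`, > 25000 nM

In an ADME assay on HEK293 cells (Homo sapiens) for cytotoxicity, with a stated time of 72 h (a higher number here means that more compound is needed for the effect, a lower number that less compound is needed), compound 1 gives > 25000 nM, which is a limit of the assay and not a number. In this assay compound 2 gives > 25000 nM, again a limit. In this assay compound 3 gives > 25000 nM, also a limit. Compound 3 therefore stands where every value shown stands, at the limit of > 25000 nM in this assay, at which 3 of the 3 values shown sit, so none of these three compounds has produced a measurable number in this assay.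

Compound 4 `Cc1cc(NC(=O)Nc2ccc(C(F)(F)F)cc2)c2ccccc2n1` differs from compound 3 in one place:

trifluoromethyl in place of acetyl on an aromatic carbon

Among the compounds with values here, no step between two measured compounds is available to gauge how much a change of this kind moves the result in this assay. Since all three measured compounds sit at the limit, the expectation for compound 4 is a step that the limit leaves unreadable from compound 3 to compound 4, that is, none beyond the scatter. Compound 4 is accordingly estimated at 30000 nM in this assay, within a range from 20000 nM to 60000 nM, most likely reported again as a limit.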

Compound 4, half-maximal effective concentration: 25000 nM
Compound 4: the middle estimate sits 1.2-fold (0.08 log units) above what was measured, and the stated range covers the measured number.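

In this assay compound 4, which carries trifluoromethyl in place of acetyl on an aromatic carbon para to a large group, gives 25000 nM as an actual number, the first one in this set. Compound 3 gives > 25000 nM as a limit of the assay and not a number. Within the data shown here, the change thus amounts to a number no higher from compound 3 to compound 4 (the limit leaves the size open) and shows that a compound of this kind can give a readable value here, though that value still lies right at the edge of the range the earlier compounds could not leave.

How much this swap really moves the result stays unreadable because nearly all the values sit at the limit: the limit of > 25000 nM in this assay, at which 3 of the 4 values shown sit. Also open, from the compounds shown here alone, is what an amine, a carboxylic acid or a longer chain on this same aromatic carbon would give.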